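The source may hold more compounds than are shown below. What is called first, only, known or untested is meant among the compounds shown, and "the series" means these compounds.

Compound 1 `COc1ccc2nc(C)cc(OCC(=O)Nc3cccc(C)c3)c2c1` gives 39800 nM in a toxicity assay on HepG2 cells (Homo sapiens) for inhibition, read by CellTiter-Glo, with a stated time of 48 h; on this read-out lower numbers stand for stronger inhibition and higher numbers for weaker inhibition.
Compound 2 `COc1ccc2nc(C)cc(OCC(=O)Nc3ccncn3)c2c1` reaches only the limit of this assay, > 100000 nM.

Compound 2 therefore stands at the weak end of what has been measured, with a limit rather than a number to its name. Going by the values given here, the one measured step, going from compound 1 to compound 2, was an at least 2.5-fold higher number from compound 1 to compound 2 (0.40 log units; beyond the scatter) and ended at the limit of > 100000 nM in this assay, at which 1 of the 2 values shown sits. Compound 3 `COc1ccc2nc(C)cc(OCC(=O)Nc3nc(C)c(C)s3)c2c1` has not yet been measured in this assay; it differs from compound 2 by 4,5-dimethyl-1,3-thiazol-2-yl in place of pyrimidin-4-yl on an amide-type nitrogen. Among the compounds with values here, no measured step exchanges one such ring for another on the amide nitrogen, so the measured steps give no direction for this change. Because compound 2 already sits at the limit of > 100000 nM in this assay, at which 1 of the 2 values shown sits, any further weakening could not show as a number. The expectation is a step of a number no higher from compound 2 to compound 3 (the limit leaves the size open) from compound 2 to compound 3. Compound 3 is thus estimated at 100000 nM, with a range from 35000 nM to 300000 nM.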

Compound 3, half-maximal inhibitory concentration: > 100000 nM
Compound 3: a limit, no number; the forecaster's own chance of this, stated with the estimate: 65%; the middle value sits exactly at the limit.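

In this assay, a second ring on the amide-type nitrogen now departs from the 3-methylphenyl of compound 1, with 4,5-dimethyl-1,3-thiazol-2-yl in place of 3-methylphenyl giving an at least 2.5-fold higher number from compound 1 to compound 3 (0.40 log units; beyond the scatter). So the move away from 3-methylphenyl gives a weaker reading with a five-membered ring as well as with the six-membered pyrimidin-4-yl of compound 2, and compound 3 gives > 100000 nM, which is a limit and not a number. The step from compound 2 to compound 3 cannot be read: the limit of > 100000 nM in this assay, at which 2 of the 3 values shown sit.

Going by these compounds, how far compound 2 and compound 3 differ from each other stays open, as neither has a number here. On these data alone, it is also open whether a plain phenyl or a pyridin-3-yl ring on this nitrogen would give a number near that of compound 1 or reach the limit.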